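Swapping the aryl group on a piperazine arylpiperazine triazinedione

This account rests on a few compounds, and the source may have more. Where it says the series, first, only, none or still open, it means among the compounds named here.

Compound 1: `CN(C)c1ccccc1N1CCN(CCCCn2ncc(=O)n(C)c2=O)CC1` with 350 nM
Compound 2: `CNc1ccccc1N1CCN(CCCCn2ncc(=O)n(C)c2=O)CC1` with 450 nM
Compound 3: `Cn1c(=O)cnn(CCCCN2CCN(c3ccccc3C#N)CC2)c1=O` with 7.3 nM

These three compounds share a core and differ only in the group on the aromatic ring attached to the piperazine nitrogen. In an assay for displacement of a labelled ligand from Adrenergic receptor alpha-1 (Homo sapiens) (on this read-out higher numbers stand for weaker inhibition and lower numbers for stronger inhibition), compound 1 gives 350 nM, the second highest of the three numbers; the step of a 1.3-fold higher number from compound 1 to compound 2 (0.11 log units; within the scatter) is within the scatter, whereas the step of a 48-fold lower number from compound 1 to compound 3 (1.68 log units; beyond the scatter) is large, as is a 62-fold lower number from compound 2 to compound 3 (1.79 log units; beyond the scatter).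

Compound 4 is `Cn1c(=O)cnn(CCCCN2CCN(c3cccc(Br)n3)CC2)c1=O`. It differs from compound 1 by 6-bromopyridin-2-yl in place of 2-(dimethylamino)phenyl on an amine nitrogen in a ring. Among the compounds with values here, no measured step replaces the whole aromatic ring, so the bearing of the known steps is only indirect: they show that changing what sits on this ring can move the number by little or by a great deal. With the whole ring exchanged, the step is expected to be of moderate size in this assay, leaning toward a lower number, roughly a 2.9-fold lower number from compound 1 to compound 4 (0.46 log units; beyond the scatter), but with wide uncertainty. Compound 4 is therefore estimated at 120 nM, within a range from 20 nM to 600 nM.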

Compound 4, inhibition constant: > 10000 nM
Compound 4 gave a limit, no number; the forecaster's own chance of this, stated with the estimate: 3%; middle value at least 83-fold (1.92 log units) away from the limit.
By their numbers in this assay, from the lowest: compound 3; then compounds 1 and 2 (each within the scatter of the next). At a limit, above all of these: compound 4.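

Compound 4 in this assay reads as a limit of the assay and not as a number: the limit of > 10000 nM in this assay, at which 1 of the 4 values shown sits. Even so, the steps can be read as an at least 28-fold higher number from compound 1 to compound 4 (1.45 log units; beyond the scatter), an at least 22-fold higher number from compound 2 to compound 4 (1.34 log units; beyond the scatter) and an at least 1300-fold higher number from compound 3 to compound 4 (3.13 log units; beyond the scatter), so replacing the whole aromatic group on the amine nitrogen of the piperazine ring can cost far more than the earlier changes on the phenyl ring showed. Keeping a phenyl ring is thus not merely a matter of fine-tuning here: of the four groups shown, 6-bromopyridin-2-yl sits alone at the weak end, with 2-cyanophenyl at the strong end.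

This step alters the ring atoms and the substituent together, and the compounds shown do not separate the two. A pyridin-2-yl group without bromine, or a bromophenyl group, would tell these two changes apart.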